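Sulfation Step Repeated on a Second Glycolipid Amide

A few compounds are considered here, and "the series" means these few. Any claim that something is new, unique, unknown or untested is made for them only; others in the source may bear on it.

Compound 1 `C=CCCC(=O)N[C@H]1[C@@H](OCCCCCCCCCCCCCCCC)O[C@H](CO)[C@@H](O)[C@@H]1O` and compound 3 `C=CCCC(=O)N[C@H]1[C@@H](OCCCCCCCCCCCCCCCC)O[C@H](CO)[C@@H](O)[C@@H]1OS(=O)(=O)O` share one core and differ only by sulfo in place of hydrogen on an oxygen on a saturated carbon. In a functional assay on U-373MG ATCC cells (Homo sapiens), read by thymidine incorporation (a lower number here means a stronger inhibitor, a higher number a weaker inhibitor), compound 1 reaches > 50 uM, which is a limit of the measurement and not a number. Compound 3 gives 33 uM in this assay. The step from compound 1 to compound 3 is an at least 1.5-fold lower number from compound 1 to compound 3 (0.18 log units; that floor lies within the scatter), and the only point on which that step rests is the limit of > 50 uM in this assay, at which 1 of the 3 values shown sits.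

Compound 2 `CCCCCCCC/C=C\CCCCCCCC(=O)N[C@H]1[C@@H](OCCCCCCCC)O[C@H](CO)[C@@H](O)[C@@H]1O` carries a different amide and a different glycoside chain; the difference between the two cores is not broken down here. In this assay compound 2 gives 13.3 uM, the lowest of the two numbers, with compound 3 standing clearly higher. Among the measured compounds shown here, compound 4 `CCCCCCCC/C=C\CCCCCCCC(=O)N[C@H]1[C@@H](OCCCCCCCC)O[C@H](CO)[C@@H](O)[C@@H]1OS(=O)(=O)O` is not yet measured and differs from compound 2 by sulfo in place of hydrogen on an oxygen on a saturated carbon, the same change as the one between compound 1 and compound 3.

Because the earlier step of an at least 1.5-fold lower number from compound 1 to compound 3 (0.18 log units; that floor lies within the scatter) sets only a floor that lies within the scatter, the corresponding step is expected to be about a 1.7-fold lower number from compound 2 to compound 4 (0.22 log units; within the scatter) in this assay. Compound 4 is therefore estimated at 8 uM, most likely between 3 uM and 25 uM.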

Compound 4, concentration for 50% inhibition: 15.6 uM
For compound 4 the middle estimate is 2.0-fold (0.29 log units) below the measured one; the measured number falls inside the stated range.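

In this assay, among the compounds shown here, the change from hydroxy to sulfooxy gives a 1.2-fold higher number from compound 2 to compound 4 (0.07 log units; within the scatter), so on the core of compound 2 it produces no step that stands clear of the scatter. Set beside the earlier step, this result neither confirms that the change carries over from one core to the other nor shows that it behaves differently on the two: the same change on two cores in this assay, an at least 1.5-fold lower number (0.18 log units; that floor lies within the scatter) from compound 1 to compound 3 and a 1.2-fold higher number (0.07 log units; within the scatter) from compound 2 to compound 4; the limit leaves it open whether they differ. From the compounds shown here alone, compound 1 stands at > 50 uM, which is a limit of the assay and not a number, so the size of the step on the first core remains unknown: the limit of > 50 uM in this assay, at which 1 of the 4 values shown sits.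

The compounds shown leave open what a phosphate or a carboxylic acid in place of the sulfo group would give in this assay. They also leave open how far the amide and the glycoside chain each contribute to the difference between the two cores, as every pair across those cores differs in both chains.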